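Isobutoxycarbonyl to benzyloxycarbonyl: compound 3 to compound 4

A few compounds are considered here, and "the series" means these few. Any claim that something is new, unique, unknown or untested is made for them only; others in the source may bear on it.

Going by the values given here, in a functional assay on MCF7 cells (Homo sapiens) for inhibition, read by MTT assay, with a stated time of 72 h (on this read-out lower numbers stand for stronger inhibition and higher numbers for weaker inhibition), compound 3 (`CC(C)COC(=O)NCCOc1ccc(Cl)cc1C(=O)N[C@H](C(=O)Nc1ccc([N+](=O)[O-])cc1Cl)C(C)C`) gives 10100 nM, the only actual number in this small set. Compound 1 (`CC(C)[C@H](NC(=O)c1cc(Cl)ccc1OCCN)C(=O)Nc1ccc([N+](=O)[O-])cc1Cl`) gives > 10000 nM, which is a limit. Compound 2 (`CC(C)[C@H](NC(=O)c1cc(Cl)ccc1OCCNC(=O)O)C(=O)Nc1ccc([N+](=O)[O-])cc1Cl`) gives > 10000 nM, also a limit.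

The next change leads to compound 4 (`CC(C)[C@H](NC(=O)c1cc(Cl)ccc1OCCNC(=O)OCc1ccccc1)C(=O)Nc1ccc([N+](=O)[O-])cc1Cl`), with phenyl in place of isopropyl on a saturated chain carbon bound to an oxygen next to a carbonyl group, so that isobutoxycarbonyl becomes benzyloxycarbonyl: phenyl in place of isopropyl on a saturated chain carbon bound to an oxygen next to a carbonyl group.

The nearest measured changes are a step that the limit leaves unreadable from compound 1 to compound 3, a step that the limit leaves unreadable from compound 2 to compound 3 and a step that the two limits leave unreadable from compound 1 to compound 2. None gives a usable size because of the limit of > 10000 nM in this assay, at which 2 of the 3 values shown sit. Among the compounds with values here, no measured pair isolates the exchange of isobutyl for benzyl, so this assay offers no direction for it.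

The expectation therefore rests on compound 3 at 10100 nM, with no step beyond the usual scatter foreseen. The expected size is a 1.3-fold lower number from compound 3 to compound 4 (0.10 log units; within the scatter). A result reported only as a limit would also be unsurprising. For compound 4 the estimated value is 8000 nM, with an expected range of 3000 nM to 20000 nM.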

Compound 4, half-maximal inhibitory concentration: > 10000 nM
Compound 4: only a limit was reported; the forecaster's own chance of this, stated with the estimate: 45%; middle value at least 1.2-fold (0.09 log units) away from the limit.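

In this assay compound 4 gives > 10000 nM, which is a limit. No step from compound 1, compound 2 or compound 3 to compound 4 can be read, because the values end at this limit: the limit of > 10000 nM in this assay, at which 3 of the 4 values shown sit.

The compounds shown leave open whether benzyloxycarbonyl and isobutoxycarbonyl differ at all on this read-out.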